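This account rests on a few compounds, and the source may have more. Where it says the series, first, only, none or still open, it means among the compounds named here.

Among the compounds with values here, compound 2 `Cc1nc(C#Cc2cccc(C(F)(F)F)c2)cs1` gives 413 nM in a functional assay on CHO cells for agonist activity at metabotropic glutamate receptor 5 (Homo sapiens), read by inositol phosphate accumulation (on this read-out lower numbers stand for stronger inhibition and higher numbers for weaker inhibition), the higher of the two numbers so far, while compound 1 `Cc1nc(C#Cc2cccc(F)c2)cs1` gives 23 nM. Within the data shown here, the only step recorded, an 18-fold higher number from compound 1 to compound 2 (1.25 log units; beyond the scatter), also concerns a group on an aromatic carbon of the same ring. Compound 3 `Cc1nc(C#Cc2cccc(OC(F)(F)F)c2)cs1` carries trifluoromethoxy in place of trifluoromethyl on an aromatic carbon. Among the measured compounds shown here, no measured step covers this exchange, so the direction is open; the one step was large, but with no closer guide compound 2 itself is the anchor. For compound 3 the expected step is a 1.2-fold higher number from compound 2 to compound 3 (0.08 log units; within the scatter). Compound 3 is estimated at 500 nM, within 150 nM to 2000 nM.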

Compound 3, half-maximal inhibitory concentration: 266 nM
For compound 3 the middle estimate is 1.9-fold (0.27 log units) above the measured one; low and high end bracket the measured number.
By their numbers in this assay, from the lowest: compound 1; then compounds 3 and 2 (each within the scatter of the next).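

In this assay, trifluoromethoxy and trifluoromethyl on this aromatic carbon cannot be told apart (a 1.6-fold lower number from compound 2 to compound 3 (0.19 log units; within the scatter)), so the added oxygen gives no change beyond the scatter. The exchange of fluoro for trifluoromethoxy gives a large step (a 12-fold higher number from compound 1 to compound 3 (1.06 log units; beyond the scatter)), so compound 2 and compound 3 both stand well clear of compound 1 at this position. No evidence on hand accounts for these numbers. Still open, on these data alone, is how a methoxy group, an amine or a carboxylic acid on this carbon would read, and whether any of them comes back towards compound 1.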